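Fluoro in place of hydrogen: compound 2 to compound 3

The source may hold more compounds than are shown below. What is called first, only, known or untested is meant among the compounds shown, and "the series" means these compounds.

Measured so far:
compound 1 `O=C(C=CNc1cc(-c2ccccc2)nn1-c1ccccc1)c1ccc(Cl)cc1`: 8070 nM
compound 2 `c1ccc(-c2ccnc3c2c(-c2ccccc2)nn3-c2ccccc2)cc1`: 28200 nM

Both were run in a functional assay on MCF7 cells (Homo sapiens) for inhibition, read by MTT assay, with a stated time of 48 h; a higher number here means a weaker inhibitor, a lower number a stronger inhibitor. Of the two numbers, compound 2 stands at the higher one, the weaker inhibitor; the gap to compound 1 is beyond the usual scatter of this assay, so the order of the two is taken as real. Within the data shown here, no pair differing in a single place has been measured, so no step is available to lean on.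

Compound 3 `Fc1ccc(-c2ccnc3c2c(-c2ccccc2)nn3-c2ccccc2)cc1` is not yet measured. The change from compound 2 to compound 3 is fluoro in place of hydrogen on an aromatic carbon, the carbon sitting para to a large group. Nothing in the two measured numbers points to a large move in this assay for this change. The expected step is a 1.3-fold lower number from compound 2 to compound 3 (0.11 log units; within the scatter), small and within the scatter. Compound 3 is expected to give about 22000 nM, with a range from 8000 nM to 60000 nM.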

Compound 3, half-maximal inhibitory concentration: 1570 nM
Beside the measured number, compound 3's estimate is 14-fold (1.15 log units) above it; measured number outside the range, below it.
By their numbers in this assay, from the lowest: compound 3; then compound 1; then compound 2.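

In this assay, among these compounds, the phenyl to 4-fluorophenyl change gives an 18-fold lower number from compound 2 to compound 3 (1.25 log units; beyond the scatter) and is the first single-place step available. Compound 1 and compound 2 differ in more than one place and could not show that this aromatic carbon, para to a large group, responds so strongly: a single fluorine atom in place of hydrogen moves the number well beyond the scatter. Nothing measured here bears on the reason for a step of this size.

On these data alone, it remains open whether this step is specific to fluoro or would also appear with chloro, methoxy, an amine or a carboxylic acid on the same carbon. Also open, as far as these compounds go, is whether fluoro in place of hydrogen on the other phenyl groups of the shared core would give a comparable step.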